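A Dimethylamino Chain on the Chloro Core

The source may report more compounds than this note shows. Statements on the series, on what has been measured and on what is new or still open speak of the compounds shown alone.

Of the compounds shown here, two have been measured. Compound 1 `CCCCNc1ccnc2cc(Cl)ccc12` is the chloro member of the pair; in a functional assay on MDA-MB-231 cells (Homo sapiens) for cytotoxicity, read by sulforhodamine B assay, with a stated time of 48 h (a lower number here means a stronger inhibitor of growth, a higher number a weaker inhibitor of growth), compound 1 gives 15900 nM, the highest of the two numbers recorded. Compound 2 `CCCCNc1ccnc2cc(F)ccc12` carries fluoro in place of chloro on the aromatic carbon, and in this assay compound 2 gives 6320 nM. Among the compounds with values here, the only measured step, a 2.5-fold lower number from compound 1 to compound 2 (0.40 log units; beyond the scatter), concerns that halogen exchange alone.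

The compound awaiting measurement, compound 3 `CN(C)CCNc1ccnc2cc(Cl)ccc12`, keeps the chloro core of compound 1 and alters the chain instead: dimethylamino in place of ethyl on a saturated chain carbon, two bonds along the chain from a nitrogen on an aromatic ring. Within the data shown here, no measured step touches this part of the molecule; the one step, from compound 1 to compound 2, sits on the aromatic ring and says nothing about a change on the chain. The expectation therefore rests on compound 1 alone and carries wide uncertainty. Compound 3 is expected to give about 12000 nM in this assay, with a range from 3000 nM to 50000 nM. Read as a step, that estimate means a 1.3-fold lower number from compound 1 to compound 3 (0.12 log units; within the scatter), which may prove no larger than the scatter.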

Compound 3, concentration for 50% growth inhibition: 8590 nM
The estimate for compound 3 lay 1.4-fold (0.15 log units) above the measured number, within the range that was stated.
By their numbers in this assay, from the lowest: compounds 2, 3 and 1 (each within the scatter of the next, the first and the last beyond it).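

Within the data shown here, this is the first reading on the chain rather than the aromatic ring: in this assay, the exchange gives a 1.9-fold lower number from compound 1 to compound 3 (0.27 log units; within the scatter). On this evidence, dimethylamino in place of ethyl on a saturated chain carbon, two bonds along the chain from a nitrogen on an aromatic ring, does not separate compound 3 from compound 1, even though the entering group brings a nitrogen and a hydrogen-bond acceptor to the chain, whereas the halogen exchange gave a 2.5-fold lower number from compound 1 to compound 2 (0.40 log units; beyond the scatter), a step printed as beyond the scatter. Nothing available explains this outcome, and no separate measurement bears on it.

The compounds shown leave open whether another group at the same place, such as a pyrrolidine, a morpholine, a hydroxyl or a carboxylic acid, would give a step beyond the scatter, and whether a longer chain ending in dimethylamino would do so. They also leave open whether the dimethylamino chain would give a similar result on the core of compound 2, since this single exchange has been read only on the chloro core of compound 1.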